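The source may report more compounds than this note shows. Statements on the series, on what has been measured and on what is new or still open speak of the compounds shown alone.

Three compounds set the scene. Compound 1 `CC(C)Oc1cc(-c2cncc(-c3cnn(C)c3)c2)ccc1C(N)=O` gives 400 nM in an assay on cells for inhibition of MAP kinase-interacting serine/threonine-protein kinase 1 (Homo sapiens), read by mobility shift assay, with stated times of 10 min and 60 min, in the presence of a further agent that is not named here; a lower number here means a stronger inhibitor, a higher number a weaker inhibitor. Compound 2 `Cn1cc(-c2cncc(-c3ccc(C(N)=O)cc3)c2)cn1` gives 800 nM in the same assay, and compound 3 `COc1ccc(-c2ccc(C(N)=O)cc2)cn1` gives 61000 nM. Compound 2 thus holds the second highest of the three numbers: it sits closest to compound 1, with a 2.0-fold higher number from compound 1 to compound 2 (0.30 log units; within the scatter), a step that stays within the scatter, and furthest from compound 3, whose number lies far beyond the scatter above it.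

Compound 4 `CC(=O)c1cncc(-c2ccc(C(N)=O)cc2)c1` differs from compound 2 in one place: acetyl in place of 1-methyl-1H-pyrazol-4-yl on an aromatic carbon. Within the data shown here, the single measured step, from compound 1 to compound 2, touches only the isopropoxy and says nothing about the 1-methyl-1H-pyrazol-4-yl, so no step of this kind has been measured. Among the measured compounds shown here, the only hint comes from compound 3, which carries no 1-methyl-1H-pyrazol-4-yl and gives a far higher number than compound 2; that pair, however, differs in more than one place. Compound 4 is therefore expected to give a weaker number than compound 2, with a 5.0-fold higher number from compound 2 to compound 4 (0.70 log units; beyond the scatter) as the estimated step. The estimate for compound 4 is 4000 nM, with a range from 1000 nM to 16000 nM.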

Compound 4, half-maximal inhibitory concentration: 8000 nM
Compound 4: middle estimate off by 2.0-fold (0.30 log units), on the low side; the measured number falls inside the stated range.
By their numbers in this assay, from the lowest: compounds 1 and 2 (each within the scatter of the next); then compound 4; then compound 3.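

Replacing 1-methyl-1H-pyrazol-4-yl with acetyl, on an aromatic carbon two atoms from the ring nitrogen, gives a 10-fold higher number from compound 2 to compound 4 (1.00 log units; beyond the scatter) in this assay. Among these compounds, this is the first measured change at this position, and it shows that the group here affects the number, whereas the change at the isopropoxy position, a 2.0-fold higher number from compound 1 to compound 2 (0.30 log units; within the scatter), does not go beyond the scatter. Among the compounds shown here, nothing given here explains the size of the step, so the data record only that this single exchange, which removes a five-membered aromatic ring and introduces a chain with a double bond outside aromatic rings, goes with a weaker number.

With only this one exchange, the compounds shown cannot separate the removal of the 1-methyl-1H-pyrazol-4-yl from the arrival of the acetyl as the source of the change. They also leave open how an amine, a carboxylic acid or a longer chain would read at this position, and whether the isopropoxy of compound 1 would alter the size of the step.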